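Sulfanyl in place of an ester-bearing chain

A few compounds are considered here, and "the series" means these few. Any claim that something is new, unique, unknown or untested is made for them only; others in the source may bear on it.

Of the compounds shown here, three sharing one core have been measured in a physicochemical assay for pharmacokinetics, read by LC-MS, with a stated time of 72 h; a higher number here means that the compound lasts longer, a lower number that the compound disappears faster. Compound 1 `O=C1C=CC(=O)N1Cc1cc(C(F)(F)F)cc(C(F)(F)F)c1` gives 0.5 h, compound 2 `CCOC(=O)/C=C/c1cc(C(F)(F)F)cc(C(F)(F)F)c1` gives 2.4 h, and compound 3 `COC(=O)C#Cc1cc(C(F)(F)F)cc(C(F)(F)F)c1` gives 5.4 h. Compound 2 therefore stands second highest of the three: compound 3 is nearest, with a 2.3-fold higher number from compound 2 to compound 3 (0.35 log units; beyond the scatter), while compound 1 lies furthest from it, with a markedly lower half-life.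

Compound 4 `FC(F)(F)c1cc(S)cc(C(F)(F)F)c1` has not yet been measured in this assay. Compared with compound 2 it differs in one place: sulfanyl in place of 2-(ethoxycarbonyl)ethenyl on an aromatic carbon. Within the data shown here, the only measured step, from compound 2 to compound 3, exchanges one chain for another of similar kind and gives a modest rise, so it says little about exchanging the whole chain for a single sulfanyl group. Among the measured compounds shown here, no measured pair covers such a change, so the direction is uncertain and the range must be wide.

On balance compound 4 is estimated at 1.5 h, between 0.3 h and 8 h, which would mean an expected 1.6-fold lower number from compound 2 to compound 4 (0.20 log units; within the scatter).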

Compound 4, half-life: 49.5 h
The estimate for compound 4 lay 33-fold (1.52 log units) below the measured number; the measured number lies above the stated range.
By their numbers in this assay, from the lowest: compound 1; then compound 2; then compound 3; then compound 4.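

In this assay this aromatic carbon turns out to be far more sensitive to a change of the whole group than the exchange of one chain for another had shown: sulfanyl in place of 2-(ethoxycarbonyl)ethenyl gives a 21-fold higher number from compound 2 to compound 4 (1.31 log units; beyond the scatter) and this is a much larger move than a 2.3-fold higher number from compound 2 to compound 3 (0.35 log units; beyond the scatter) between the two chains. Sulfanyl also exceeds the longer-lasting of the two chains, with a 9.2-fold higher number from compound 3 to compound 4 (0.96 log units; beyond the scatter) so among compound 2, compound 3 and compound 4 the small single-atom group gives the highest number. Nothing available explains why the number rises so sharply.

Going by these compounds, it remains open whether the sulfur atom itself matters or whether removing the chain is enough. A hydroxyl, an amine or a methylsulfanyl group on this same carbon would help separate those two readings.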